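The source may report more compounds than this note shows. Statements on the series, on what has been measured and on what is new or still open speak of the compounds shown alone.

Measured so far: compound 1 `COc1ccc(-c2nc(C)c(C(=O)CSc3nc(-c4ccc(OC)cc4)c(C#N)c(=O)[nH]3)s2)cc1` gives 11.5%; compound 2 `COc1ccc(-c2nc(C)c(C(=O)CSc3nc(-c4cccc(OC)c4)c(C#N)c(=O)[nH]3)s2)cc1` gives 12.4%.

Compound 2 stands highest of the two numbers in a functional assay on U-87MG ATCC cells for antiproliferative activity against U-87 MG (Homo sapiens), read by MTT assay, with a stated time of 48 h, tested at 100 uM (on this read-out higher numbers stand for a weaker effect at the one concentration tested and lower numbers for a stronger effect), with compound 1 nearest, and the move from 4-methoxyphenyl to 3-methoxyphenyl gave a number 0.9 percentage points higher from compound 1 to compound 2 (within the scatter), within the scatter. Compound 3 `COc1ccc(-c2nc(C)c(C(=O)CSc3nc(-c4ccc(OC)c(OC)c4)c(C#N)c(=O)[nH]3)s2)cc1` differs from compound 2 by methoxy in place of hydrogen on an aromatic carbon. For the measured compounds named here, no measured step adds a methoxy group; the only step known is the positional change from compound 1 to compound 2, which is within the scatter and suggests little sensitivity of this assay to methoxy placement. For compound 3 the expected step is a number 0.6 percentage points higher from compound 2 to compound 3 (within the scatter), with an estimate of 13% (range 5% to 25%).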

Compound 3, a percentage reported as activity, at one concentration (the size of the read-out at that concentration, not a potency): 5.39%
The estimate for compound 3 lay 7.6 percentage points above the measured number, and the stated range covers the measured number.
By their numbers in this assay, from the lowest: compounds 3, 1 and 2 (each within the scatter of the next).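

Going from one methoxy to the 3,4-dimethoxyphenyl ring in this assay gives a number 7 percentage points lower from compound 2 to compound 3 (within the scatter) and a number 6.1 percentage points lower from compound 1 to compound 3 (within the scatter). The earlier pair covered only a shift of one methoxy, whereas these steps show that a further methoxy, ortho to a methoxy group and para to a large group, also gives no step beyond the scatter. No evidence on hand bears on these steps.

Open, from the compounds shown here alone, is whether an amine, a carboxylic acid or a longer alkoxy chain at this place would give a step beyond the scatter. Also open, going by these compounds, is how a phenyl ring carrying no methoxy would read.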